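Aryl change on the ring amine: compound 4 expected

The source may hold more compounds than are shown below. What is called first, only, known or untested is meant among the compounds shown, and "the series" means these compounds.

Measured so far:
compound 1 `Nc1scc(CN2CCN(c3ccc(Cl)cc3Cl)CC2)c1C(=O)c1ccc(Cl)cc1` gives 0% in an assay on CHO cells for displacement of a labelled ligand from adenosine receptor A1 (Homo sapiens), read by scintillation counting, with a stated time of 120 min, tested at 10 uM; a lower number here means less inhibition, a higher number more inhibition at the concentration tested (going by the name of the read-out)
compound 2 `Nc1scc(CN2CCN(c3cccc4ccccc34)CC2)c1C(=O)c1ccc(Cl)cc1` gives 1% in this assay
compound 3 `Nc1scc(CN2CCN(c3ccccc3F)CC2)c1C(=O)c1ccc(Cl)cc1` gives 4% in this assay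

Compound 1 stands lowest of the three numbers, but only within the scatter: a number 1 percentage points higher from compound 1 to compound 2 (within the scatter), and a number 4 percentage points higher from compound 1 to compound 3 (within the scatter). Likewise a number 3 percentage points higher from compound 2 to compound 3 (within the scatter). Every aryl exchange on the ring amine measured so far has therefore left the read-out unchanged beyond the scatter.

Compound 4 `Nc1scc(CN2CCN(c3ccc(F)cc3F)CC2)c1C(=O)c1ccc(Cl)cc1` differs from compound 1 in one place: 2,4-difluorophenyl in place of 2,4-dichlorophenyl on an amine nitrogen in a ring. Among the measured compounds shown here, no measured step makes this exact change, so the expectation rests on the three flat steps above. No step beyond the scatter is expected in this assay; compound 4 is estimated at 2%, range -6% to 10%, which means an expected a number 2 percentage points higher from compound 1 to compound 4 (within the scatter).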

Compound 4, a percentage reported as inhibition, at one concentration (the size of the read-out at that concentration, not a potency): 1%
Compound 4: middle estimate off by 1 percentage points, on the high side; low and high end bracket the measured number.
By their numbers in this assay, from the lowest: compounds 1, 2, 4 and 3 (each within the scatter of the next).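

In this assay 2,4-difluorophenyl in place of 2,4-dichlorophenyl gives a number 1 percentage points higher from compound 1 to compound 4 (within the scatter) and so shows that exchanging both chlorines for fluorines on the amine nitrogen leaves the read-out flat. Fluoro in place of hydrogen on an aromatic carbon gives a number 3 percentage points lower from compound 3 to compound 4 (within the scatter) and the exchange of naphthalen-1-yl gives no change at the digits printed from compound 2 to compound 4 (within the scatter) so all four aryl groups lie within the scatter of one another. No evidence at hand bears on this flat read-out.

Going by these compounds, whether a pyridyl or a methoxyphenyl group on this nitrogen would move the read-out stays open. So does whether any change elsewhere on the shared core would.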